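Trading hexyl for phenyl on compound 2

This account rests on a few compounds, and the source may have more. Where it says the series, first, only, none or still open, it means among the compounds named here.

In a physicochemical assay for lipophilicity (a lower number here means a more polar compound, a higher number a more lipophilic compound), compound 2 `CCCCCCCCC(=O)Nc1nc2ccccc2n1CCC` gives 5.7, the highest of three numbers, while compound 3 `CCCn1c(NC(=O)/C=C/c2ccccc2)nc2ccccc21` gives 4.6 and compound 1 `CCCCC(=O)Nc1nc2ccccc2n1CCC` gives 3.9. Compound 4 `CCCn1c(NC(=O)CCc2ccccc2)nc2ccccc21` has phenyl in place of hexyl on a saturated chain carbon, two bonds along the chain from a carbonyl carbon. Among the measured compounds shown here, the only measured step that bears on this is a chain change, butyl in place of hydrogen, which gave a number 1.80 log units higher from compound 1 to compound 2 (beyond the scatter). Compound 3 also carries a phenyl and sits at 4.6, so a sizeable fall in this assay is expected. The expected change is a number 1.20 log units lower from compound 2 to compound 4 (beyond the scatter). For compound 4 the estimated value is 4.5, with an expected range from 4.1 to 4.9.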

Compound 4, partition coefficient: 4.6
Estimate against measurement, compound 4: 0.10 log units below, within the range that was stated.
By their numbers in this assay, from the lowest: compound 1; then compounds 3 and 4 (each within the scatter of the next); then compound 2.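

Until now, this position had shown only a chain growing longer. Here, in this assay, a ring replaces a chain of the same 6 heavy atoms, giving a number 1.10 log units lower from compound 2 to compound 4 (beyond the scatter), so the chain and the ring are not interchangeable at this position even at equal atom count. Phenyl still leaves a number 0.70 log units higher from compound 1 to compound 4 (beyond the scatter), and no measurement here accounts for either step. On these data alone, an amine or a carboxylic acid on the phenyl remains open, as does how a longer chain carrying the phenyl would read.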